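The compounds below may be only part of what the source reports. "The series", "measured", "known", "first", "only" and "open" are said of these compounds alone.

Measured so far in a functional assay on MCF7 cells (Homo sapiens) for inhibition, read by trypan blue exclusion, with a stated time of 72 h; a lower number here means a stronger inhibitor of growth, a higher number a weaker inhibitor of growth:
- compound 1 `CC/C(=C(\c1ccccc1)c1ccc(NC(=O)C(C)C)cc1)c1ccccc1`: > 30000 nM (a limit)
- compound 2 `CC/C(=C(/c1ccc(NC(=O)C(C)C)cc1)c1ccc(OC)cc1)c1ccccc1`: > 30000 nM (a limit)

In this assay compound 2 gives > 30000 nM as a limit and not a number. Within the data shown here, the series so far consists only of the limit of > 30000 nM in this assay, at which 2 of the 2 values shown sit, and offers no measured number.

Compound 3 `CC/C(=C(/c1ccc(NC(=O)C(C)C)cc1)c1ccc(OC)cc1)c1ccc(OCc2ccccc2)cc1` follows from compound 2 by benzyloxy in place of hydrogen on an aromatic carbon in the form of benzyloxy in place of hydrogen on an aromatic carbon, para to a large group.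

Among the measured compounds shown here, one measured step bears on this change, since it too replaces hydrogen on an aromatic carbon: a step that the two limits leave unreadable from compound 1 to compound 2 with methoxy entering. It gives neither a size nor a direction to carry over.

The expectation therefore rests on compound 2, whose > 30000 nM is a limit. On these data no step beyond the scatter can be expected in this assay and no direction can be assigned. The expected change is a number no higher from compound 2 to compound 3 (the limit leaves the size open) as an estimate. In this assay compound 3 is estimated at 30000 nM with an expected range of 10000 nM to 60000 nM and will most likely be reported only as a limit.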

Compound 3, concentration for 50% growth inhibition: 29000 nM
Compound 3: middle estimate off by 1.0-fold (0.01 log units), on the high side; measured number inside the range.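

In this assay, among these compounds, compound 3 gives 29000 nM, the first number and not a limit, so a readable value now exists for the shared core with benzyloxy on an aromatic carbon, para to a large group. The change reads as an at least 1.0-fold lower number from compound 2 to compound 3 (0.01 log units; that floor lies within the scatter), which is a floor and not a measured size, and it does not establish any gain from benzyloxy in place of hydrogen. The true size stays open because the starting value of compound 2 is a limit and not a number: the limit of > 30000 nM in this assay, at which 2 of the 3 values shown sit.

Among the compounds shown here, the step from compound 1 to compound 2 cannot be read, which leaves the series with no step measured between two numbers and no size to compare with the benzyloxy change. Open questions are whether a hydroxyl, an amine or a carboxylic acid at this place would also give a number in this assay, and whether a number there needs the aromatic ring of benzyloxy or would also appear with a plain longer chain on the oxygen.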